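Aryl swap on a sulfonamide nitrogen: compound 4 from compound 1

The source may report more compounds than this note shows. Statements on the series, on what has been measured and on what is new or still open speak of the compounds shown alone.

Compound 1 `O=S(=O)(Nc1cccc(Cl)c1)c1ccc(-c2cnc(C3CC3)o2)cc1` gives 54200 nM in a functional assay on cells (leukaemia cell line, Homo sapiens) for inhibition, read by sulforhodamine B assay, with a stated time of 48 h (a higher number here means a weaker inhibitor of growth, a lower number a stronger inhibitor of growth), the lowest of the three numbers, though none of its steps to the others leaves the scatter. Compound 2 `O=S(=O)(Nc1ccc(Br)c(Cl)c1)c1ccc(-c2cnc(C3CC3)o2)cc1` gives 70300 nM and compound 3 `COc1cc(NS(=O)(=O)c2ccc(-c3cnc(C4CC4)o3)cc2)ccc1F` gives 75700 nM. The step of a 1.3-fold higher number from compound 1 to compound 2 (0.11 log units; within the scatter) and the step of a 1.4-fold higher number from compound 1 to compound 3 (0.15 log units; within the scatter) both stay within the scatter, so the aryl group on the sulfonamide nitrogen has so far moved the number little. Compound 4 `Cc1cc(F)cc(NS(=O)(=O)c2ccc(-c3cnc(C4CC4)o3)cc2)c1` differs from compound 1 by 3-fluoro-5-methylphenyl in place of 3-chlorophenyl on a sulfonamide nitrogen. Because the changes a 1.3-fold higher number from compound 1 to compound 2 (0.11 log units; within the scatter) and a 1.4-fold higher number from compound 1 to compound 3 (0.15 log units; within the scatter) were small, no step beyond the scatter is expected. The estimate for compound 4 in this assay is 60000 nM, between 25000 nM and 140000 nM, a step of a 1.1-fold higher number from compound 1 to compound 4 (0.04 log units; within the scatter).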

Compound 4, concentration for total growth inhibition: 7250 nM
Compound 4: middle estimate off by 8.3-fold (0.92 log units), on the high side; the whole stated range lies above it.
By their numbers in this assay, from the lowest: compound 4; then compounds 1, 2 and 3 (each within the scatter of the next).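

In this assay, the aryl group on a sulfonamide nitrogen turns out to be able to move the number: 3-fluoro-5-methylphenyl gives a 7.5-fold lower number from compound 1 to compound 4 (0.87 log units; beyond the scatter), along with a 9.7-fold lower number from compound 2 to compound 4 (0.99 log units; beyond the scatter) and a 10-fold lower number from compound 3 to compound 4 (1.02 log units; beyond the scatter), whereas the steps among the three earlier compounds stayed within the scatter. Compound 4 is therefore the strongest inhibitor of growth of the four. Nothing measured here accounts for this step. Which of the fluoro and methyl groups carries the step remains open. Also open, from the compounds shown here alone, is whether an amine or a carboxylic acid on this phenyl ring would keep it.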